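Adding a Methyl to Compound 1: What to Expect

This account rests on a few compounds, and the source may have more. Where it says the series, first, only, none or still open, it means among the compounds named here.

Measured so far in a functional assay on HeLa cells (Homo sapiens) for inhibition, read by CCK-8 assay, with a stated time of 48 h; a lower number here means a stronger inhibitor, a higher number a weaker inhibitor:
Compound 1 `c1ccc(C2=NN(C3=NC(c4ccccc4)CS3)C(c3cccc4ccccc34)C2)cc1` gives 5320 nM.
Compound 2 `Fc1ccc(C2=NN(C3=NC(c4ccccc4)CS3)C(c3ccc4ccccc4c3)C2)cc1` gives 9730 nM.
Compound 3 `Cc1ccc(C2=NN(C3=NC(c4ccccc4)CS3)C(c3ccc4ccccc4c3)C2)cc1C` gives 950 nM.

Compound 1 stands second highest of the three numbers in this assay. Compound 2 lies within the scatter of it, so no order between them is claimed, while compound 3 lies beyond the scatter on the lower side. Compound 4 `Cc1ccc(C2=NN(C3=NC(c4ccccc4)CS3)C(c3cccc4ccccc34)C2)cc1` differs from compound 1 in one place: methyl in place of hydrogen on an aromatic carbon. Among the measured compounds shown here, only one measured step bears on such a change: a 10-fold lower number from compound 2 to compound 3 (1.01 log units; beyond the scatter). That step exchanged a fluorine for two methyls on the same ring at once, so it is not the same change, but it shows that compound 3, which carries methyls on this ring, gave the lowest number here. A smaller share of that shift is therefore expected. Compound 4 is expected to give 2000 nM in this assay. The range estimated for compound 4 runs from 700 nM to 6000 nM. The expected step is a 2.7-fold lower number from compound 1 to compound 4 (0.42 log units; beyond the scatter), a modest lowering.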

Compound 4, half-maximal inhibitory concentration: 4290 nM
For compound 4 the middle estimate is 2.1-fold (0.33 log units) below the measured one; low and high end bracket the measured number.
By their numbers in this assay, from the lowest: compound 3; then compounds 4, 1 and 2 (each within the scatter of the next, the first and the last beyond it).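

In this assay, going from phenyl to 4-methylphenyl gives a 1.2-fold lower number from compound 1 to compound 4 (0.09 log units; within the scatter), so compound 1 and compound 4 cannot be told apart. Among the compounds shown here, this is the first view of a methyl entering alone, in place of a hydrogen and para to a large group. The earlier step, a 10-fold lower number from compound 2 to compound 3 (1.01 log units; beyond the scatter), replaced 4-fluorophenyl with 3,4-dimethylphenyl, and its size beyond the scatter does not appear with this single methyl on the core of compound 1. Nothing available explains this result.

Still open, going by these compounds, is whether 3,4-dimethylphenyl on the core of compound 1 would give a step beyond the scatter. On these data alone, it is equally open whether another group at this place, such as methoxy or an amine, would do so.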